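The compounds below may be only part of what the source reports. "The series", "measured", "known", "first", "only" and "open" are said of these compounds alone.

Compound 1 `COc1ccc([C@H]2CC(=O)N(C(C)=O)C2)cc1OC1CCCC1` carries an acetyl group on the ring nitrogen of the shared core. In a functional assay on HEK293 cells (Homo sapiens) for cytotoxicity (a higher number here means that more compound is tolerated, a lower number that less compound is tolerated), compound 1 gives > 10000 nM, which is a limit of the assay rather than a number. Compound 2 `COc1ccc([C@H]2CC(=O)N(c3cc(N)cc(N)c3)C2)cc1OC1CCCC1` gives > 10000 nM, also a limit. Compound 3 `COc1ccc([C@H]2CC(=O)N(c3cc(N)cc(F)c3)C2)cc1OC1CCCC1` gives > 10000 nM, again a limit. Because all three values sit at the limit of > 10000 nM in this assay, at which 3 of the 3 values shown sit, the steps a step that the two limits leave unreadable from compound 1 to compound 2 and a step that the two limits leave unreadable from compound 1 to compound 3 cannot be read, and the same holds for a step that the two limits leave unreadable from compound 2 to compound 3. Compound 4 `COc1ccc([C@H]2CC(=O)N(c3ccncc3)C2)cc1OC1CCCC1` differs from compound 1 by pyridin-4-yl in place of acetyl on an amide-type nitrogen in a ring. The two measured swaps of the acetyl group at this nitrogen left the read-out beyond the limit, so for compound 4 no change beyond the scatter is expected in a step that the limit leaves unreadable from compound 1 to compound 4. Compound 4 is therefore estimated at 15000 nM, within 7000 nM to 40000 nM.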

Compound 4, half-maximal cytotoxic concentration: > 10000 nM
Compound 4: only a limit was reported; the forecaster's own chance of this, stated with the estimate: 85%; the middle value is on the limit's open side.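

In this assay compound 4 gives > 10000 nM, again a limit. The steps linking it to compound 1, compound 2 and compound 3 cannot be read: the limit of > 10000 nM in this assay, at which 4 of the 4 values shown sit. Going by these compounds, the concentration at which any of these four compounds becomes cytotoxic remains open.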